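The source may report more compounds than this note shows. Statements on the series, on what has been measured and on what is new or still open speak of the compounds shown alone.

Measured so far:
Compound 1 `Cc1ccccc1Nc1nc(NC2CCCCC2)ncc1Cl` — in a functional assay on Jurkat cells (Homo sapiens) for inhibition, read by CCK-8 assay, with a stated time of 48 h (a higher number here means a weaker inhibitor of growth, a lower number a stronger inhibitor of growth), compound 1 gives > 100000 nM, which is a limit of the assay and not a number.
Compound 2 `Cc1ccc(Nc2ncc(Cl)c(Nc3ccccc3C)n2)cc1` — in this assay compound 2 gives > 100000 nM, again a limit rather than a number.
Compound 3 `CN1CCN(c2ccc(Nc3ncc(Cl)c(NCc4ccc(F)cc4)n3)nc2)CC1` — in this assay compound 3 gives > 100000 nM, also a limit.

Compound 3 therefore stands at the limit, together with every other measured compound; the relevant observation is the limit of > 100000 nM in this assay, at which 3 of the 3 values shown sit. For the measured compounds named here, the only measured step between compounds that differ in one place is a step that the two limits leave unreadable from compound 1 to compound 2, and it runs from one limit to another, so its size cannot be read. Going by the values given here, no measured step bears on the change now in question.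

Compound 4 `COc1ccc(Nc2nc(Nc3ccc(N4CCN(C)CC4)cn3)ncc2Cl)cc1` differs from compound 3 by 4-methoxyphenyl in place of 4-fluorobenzyl on a nitrogen on an aromatic ring. With no readable step in the series and all three values sitting at the limit, nothing in the data points to a shift in this assay in either direction beyond the scatter. The expected step is a number no higher from compound 3 to compound 4 (the limit leaves the size open), and compound 4 is most likely to return a limit again rather than a number. Compound 4 is estimated at 100000 nM, with an expected range from 30000 nM to 300000 nM.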

Compound 4, concentration for 50% growth inhibition: 11200 nM
Beside the measured number, compound 4's estimate is 8.9-fold (0.95 log units) above it; the measured number lies below the stated range.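

In this assay, for the compounds shown here, 4-methoxyphenyl in place of 4-fluorobenzyl on a nitrogen on an aromatic ring gives an at least 8.9-fold lower number from compound 3 to compound 4 (0.95 log units; beyond the scatter), the first readable step, though its size stays open on one side since the starting value is a limit. Going by these compounds alone, compound 4 gives 11200 nM, the first number. This nitrogen is thus a place where a change in the group can move the read-out off the limit. The other compounds stay at a limit, which is not a number: the limit of > 100000 nM in this assay, at which 3 of the 4 values shown sit.

The step replaces benzyl with phenyl and fluoro with methoxy at once, and the compounds shown do not separate the two changes. Going by these compounds, how 4-fluorophenyl, 4-methoxybenzyl or a phenyl carrying an amine on this nitrogen would read remains open.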